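Lactam-capped hydroxamates: swapping the anilide for cyclopentylamide

The compounds below may be only part of what the source reports. "The series", "measured", "known", "first", "only" and "open" are said of these compounds alone.

Compound 1 `O=C(CCCCC[C@H](NC(=O)[C@@H]1CCCC(=O)N1)C(=O)Nc1ccccc1)NO` is the reference in this set. In an assay on isolated protein for inhibition of histone deacetylase 11 (Homo sapiens), read by fluorescence (on this read-out lower numbers stand for stronger inhibition and higher numbers for weaker inhibition), compound 1 gives 47 nM, the lowest of the three numbers measured. Compound 2 `O=C(CCCCC[C@H](NC(=O)C1CCCNC1=O)C(=O)Nc1ccccc1)NO` gives 255 nM and compound 3 `O=C(CCCCC[C@H](NC(=O)C1CCNC1=O)C(=O)Nc1ccccc1)NO` gives 150 nM. Both comparisons with compound 1 concern the lactam on the carbonyl carbon: a 5.4-fold higher number from compound 1 to compound 2 (0.73 log units; beyond the scatter) and a 3.2-fold higher number from compound 1 to compound 3 (0.50 log units; beyond the scatter), each a modest step beyond the scatter. The step between the two smaller lactams, a 1.7-fold lower number from compound 2 to compound 3 (0.23 log units; within the scatter), stays within the scatter.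

Compound 4 `O=C(CCCCC[C@H](NC(=O)[C@@H]1CCCC(=O)N1)C(=O)NC1CCCC1)NO` keeps the lactam of compound 1 and alters the other end: cyclopentyl in place of phenyl on an amide-type nitrogen. For the measured compounds named here, none of the measured steps touches the amide-type nitrogen, so there is no direct precedent for this change; the only information is that changes at the opposite end of the shared core moved the number modestly and never by more than the step to compound 2. With the lactam of compound 1 retained, compound 4 is expected to stay close to compound 1, with the step of a 1.5-fold higher number from compound 1 to compound 4 (0.17 log units; within the scatter) estimated to lie within or only modestly beyond the scatter in either direction. The estimate for compound 4 in this assay is therefore 70 nM, with a range from 25 nM to 200 nM.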

Compound 4, half-maximal inhibitory concentration: 1440 nM
Estimate against measurement, compound 4: 21-fold (1.31 log units) below, outside the stated range (above it).
By their numbers in this assay, from the lowest: compound 1; then compounds 3 and 2 (each within the scatter of the next); then compound 4.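

Notes on the amide-type nitrogen: in this assay this end of the shared core proves far more sensitive than the lactam end, since cyclopentyl in place of phenyl gives a 31-fold higher number from compound 1 to compound 4 (1.49 log units; beyond the scatter) as a large step, while the lactam changes gave only the modest 5.4-fold higher number from compound 1 to compound 2 (0.73 log units; beyond the scatter) and a 3.2-fold higher number from compound 1 to compound 3 (0.50 log units; beyond the scatter) steps. The group that leaves and the group that enters have the same counts of hydrogen-bond donors and acceptors and the same lack of net charge, so those counts do not separate them; what differs is a six-membered aromatic ring of carbon only against a five-membered non-aromatic ring of carbon only. Nothing available bears on the reason for this loss.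

Open, as far as these compounds go, is whether ring size or aromatic character carries the step, a question that cyclohexyl on the same nitrogen would help to separate, while benzyl would test a longer link to the phenyl ring. Also open, from the compounds shown here alone, is whether cyclopentyl costs as much when paired with the lactams of compound 2 and compound 3.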